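Pyridin-3-yl for Pyridin-2-yl: Effect on Cell Viability

This account rests on a few compounds, and the source may have more. Where it says the series, first, only, none or still open, it means among the compounds named here.

Three compounds, compound 1 `COc1cccc(S(=O)(=O)/C=C/c2ccccn2)c1`, compound 2 `COc1ccc(S(=O)(=O)/C=C/c2ccccn2)cc1` and compound 3 `COc1cccc(S(=O)(=O)/C=C/c2cccnc2)c1`, were examined in an ADME assay on BV-2 cells (Mus musculus) for cytotoxicity, with a stated time of 24 h, tested at 10 uM; a lower number here means a stronger effect, a higher number a weaker effect of the compound at the concentration tested. In this assay compound 1 gives 100%, compound 2 gives 100% and compound 3 gives 100%. The difference between the cores of compound 1 and compound 2 is not broken down here. Compound 3 differs from compound 1 by pyridin-3-yl in place of pyridin-2-yl on a double-bonded chain carbon bound to a double-bonded chain carbon, and that change gave no change at the digits printed from compound 1 to compound 3 (within the scatter). Compound 4 `COc1ccc(S(=O)(=O)/C=C/c2cccnc2)cc1` has not yet been measured; it differs from compound 2 by pyridin-3-yl in place of pyridin-2-yl on a double-bonded chain carbon bound to a double-bonded chain carbon, the same change at the same place. Because the earlier change gave no change at the digits printed from compound 1 to compound 3 (within the scatter), the expected step is no change at the digits printed from compound 2 to compound 4 (within the scatter). Compound 4 is therefore estimated at 100%, with 90% to 100% as its expected range.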

Compound 4, a percentage reported as activity, at one concentration (the size of the read-out at that concentration, not a potency): 99.5%
The estimate for compound 4 lay 0.5 percentage points above the measured number, within the range that was stated.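

Carried onto the core of compound 2, pyridin-3-yl in place of pyridin-2-yl on a double-bonded chain carbon gave a number 0.5 percentage points lower from compound 2 to compound 4 (within the scatter) in this assay. Set beside the earlier step, the change behaved alike on both cores: the same change on two cores in this assay, no change at the digits printed (within the scatter) from compound 1 to compound 3 and a number 0.5 percentage points lower (within the scatter) from compound 2 to compound 4, 0.5 percentage points apart, within the scatter of two such steps. This shows that the change carried between these two cores without a visible effect on this read-out, but it rests on a single concentration at which none of the four compounds departs from the others, so it does not show that the change would carry over on a core where the read-out falls.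

The compounds shown leave open how pyridin-4-yl would read in the same place. They also leave open what an amine or a carboxylic acid would do in place of the methoxy group.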